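A few compounds are considered here, and "the series" means these few. Any claim that something is new, unique, unknown or untested is made for them only; others in the source may bear on it.

Compound 1 `COc1cc(-c2nn(-c3cccc(NC(=O)c4cccc(C(F)(F)F)c4)c3)cc2-c2ccncc2)ccc1Cl` and compound 2 `COc1cc(-c2nn(-c3cccc(NC(=O)Nc4cccc(C(F)(F)F)c4)c3)cc2-c2ccncc2)ccc1Cl` share the same core and differ at a single spot: in compound 2 a (3-(trifluoromethyl)phenyl)amino group takes the place of 3-(trifluoromethyl)phenyl on a carbonyl carbon. In a functional assay on A498 cells (Homo sapiens) for inhibition, read by sulforhodamine B assay, with a stated time of 48 h (on this read-out higher numbers stand for weaker inhibition of growth and lower numbers for stronger inhibition of growth), compound 1 gives 2780 nM, and compound 2 gives 4040 nM. The step of a 1.5-fold higher number from compound 1 to compound 2 (0.16 log units; within the scatter) stays within the scatter, so these two compounds cannot be told apart on this read-out. Going by the values given here, compound 2 nevertheless carries the larger of the two numbers measured so far, with compound 1 its only neighbour.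

Compound 3 `COc1cc(-c2nn(-c3cccc(NC(=O)Nc4ccc(Cl)c(C(F)(F)F)c4)c3)cc2-c2ccncc2)ccc1Cl` has not been measured yet. It differs from compound 2 by one change: chloro in place of hydrogen on an aromatic carbon. Among the compounds with values here, none of the measured steps touches this part of the molecule; the only step known, from compound 1 to compound 2, concerns the carbonyl carbon and was small. The numbers therefore give no direction for this change, and the expected step is a 1.6-fold lower number from compound 2 to compound 3 (0.21 log units; within the scatter), not beyond the scatter. Compound 3 is estimated to give 2500 nM in this assay, with a range from 900 nM to 7000 nM.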

Compound 3, concentration for total growth inhibition: 6970 nM
Estimate against measurement, compound 3: 2.8-fold (0.45 log units) below, and the stated range covers the measured number.
By their numbers in this assay, from the lowest: compounds 1, 2 and 3 (each within the scatter of the next, the first and the last beyond it).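

The ring position ortho to a trifluoromethyl group and para to a large group now has its first reading: chloro in place of hydrogen gives a 1.7-fold higher number from compound 2 to compound 3 (0.24 log units; within the scatter) in this assay and so does not separate the two compounds on this read-out. Going by these compounds alone, the wider comparison, with (4-chloro-3-(trifluoromethyl)phenyl)amino in place of 3-(trifluoromethyl)phenyl on the carbonyl carbon, gives a 2.5-fold higher number from compound 1 to compound 3 (0.40 log units; beyond the scatter) and is the only pair of the three that can be told apart, though the step is modest. Nothing shown here offers an explanation for these numbers.

A single chloro cannot show how this ring position responds to other groups, so a fluoro, a methoxy, an amine or a carboxylic acid at the same place could each give a different answer. From the compounds shown here alone, it also remains open whether chloro at this position would give a similar step on the compound 1 scaffold, where the 3-(trifluoromethyl)phenyl group sits directly on the carbonyl carbon, and thus whether the two parts of the wider comparison act independently.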